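Taking the carbonyl side chain off compound 2

The source may report more compounds than this note shows. Statements on the series, on what has been measured and on what is new or still open speak of the compounds shown alone.

Of the compounds shown here, two sharing a core have been measured for cytotoxicity. In an ADME assay on L6 cells (Rattus norvegicus) for cytotoxicity, read by resazurin assay, with a stated time of 72 h (a lower number here means a stronger inhibitor, a higher number a weaker inhibitor), compound 1 `NC1CC2(N3CCCC3)CC(c3ccccc3)C1C(c1ccccc1)C2` gives 38100 nM. In this assay, compound 2 `CN1CCN(CCC(=O)NC2CC3(N4CCCCC4)CC(c4ccccc4)C2C(c2ccccc2)C3)CC1` gives 61100 nM. Among the measured compounds shown here, compound 2 therefore stands within the usual scatter of compound 1, the only other compound measured, and both values sit in the same tens-of-thousands range of the read-out.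

The next compound to be measured is compound 3 `NC1CC2(N3CCCCC3)CC(c3ccccc3)C1C(c1ccccc1)C2`. It is derived from compound 2 by a single change on an amine nitrogen: hydrogen takes the place of (2-(4-methylpiperazin-1-yl)ethyl)carbonyl, (hydrogen in place of (2-(4-methylpiperazin-1-yl)ethyl)carbonyl on an amine nitrogen). That leaves an amino group where compound 2 has ((2-(4-methylpiperazin-1-yl)ethyl)carbonyl)amino.

For the measured compounds named here, no step between measured compounds shows what this exchange does, so the expectation rests only on the narrow spread of the two known values. A modest move towards a lower number in this assay is expected, an estimated 1.9-fold lower number from compound 2 to compound 3 (0.28 log units; within the scatter), and this may not clear the scatter. The expected value for compound 3 is 32000 nM, with an estimated range from 13000 nM to 75000 nM.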

Compound 3, half-maximal inhibitory concentration: 35000 nM
For compound 3 the middle estimate is 1.1-fold (0.04 log units) below the measured one, within the range that was stated.
By their numbers in this assay, from the lowest: compounds 3, 1 and 2 (each within the scatter of the next).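

In this assay, taking (2-(4-methylpiperazin-1-yl)ethyl)carbonyl off the amine nitrogen gives a 1.7-fold lower number from compound 2 to compound 3 (0.24 log units; within the scatter) and so shows that this whole side chain, with its six-membered ring and 11 heavy atoms, can be replaced by hydrogen without a step beyond the scatter. The result also allows a second reading on the shared core, where piperidin-1-yl in place of pyrrolidin-1-yl on a saturated ring carbon gives a 1.1-fold lower number from compound 1 to compound 3 (0.04 log units; within the scatter) and likewise stays within the scatter, so neither of the two places has yet shown a real difference in this read-out.

Going by these compounds, it remains open whether a smaller group on the amine nitrogen, such as acetyl or methanesulfonyl, or a side chain ending in a carboxylic acid, would give a step beyond the scatter. On these data alone, it is equally open whether morpholin-4-yl or a longer chain on the saturated ring carbon would separate from the values seen so far. Nothing given here offers an explanation for either step.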